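Ring isomer at the assay limit: compound 2 to compound 4

The source may hold more compounds than are shown below. What is called first, only, known or untested is meant among the compounds shown, and "the series" means these compounds.

Measured so far:
compound 1 `CCNC(=O)c1sc(-c2ccccc2)nc1O`: > 100000 nM, a limit
compound 2 `O=C(c1sc(-c2cccc(F)c2)nc1O)N1CCCOC1`: > 100000 nM, a limit
compound 3 `CCOC(=O)c1sc(-c2ccccc2)nc1CO`: > 100000 nM, a limit

In an assay on HEK293 cells for inhibition of transient receptor potential cation channel subfamily M member 8 (Homo sapiens), read by FLIPR, with stated times of 5 min and 3 min (on this read-out lower numbers stand for stronger inhibition and higher numbers for weaker inhibition), none of these is a number. Compound 2 stands at the limit of > 100000 nM in this assay, at which 3 of the 3 values shown sit. Nothing shown separates compound 2 from compound 1 or compound 3.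

Compound 4 `O=C(c1sc(-c2cccc(F)c2)nc1O)N1CCCCO1` differs from compound 2 by a group of 6 heavy atoms (4 carbon, 1 nitrogen, 1 oxygen; one six-membered non-aromatic ring with 2 hetero atoms) in place of a group of 6 heavy atoms (4 carbon, 1 nitrogen, 1 oxygen; one six-membered non-aromatic ring with 2 hetero atoms), on a carbonyl carbon; the two have the same atoms, joined differently. Among the measured compounds shown here, no step between measured compounds exists on this read-out. With compound 2 only at a limit, the expected step is a number no higher from compound 2 to compound 4 (the limit leaves the size open), nothing beyond the usual scatter. Compound 4 is expected at 100000 nM, between 30000 nM and 300000 nM, most likely again reported only as a limit.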

Compound 4, half-maximal inhibitory concentration: 167 nM
The estimate for compound 4 lay 600-fold (2.78 log units) above the measured number, and the stated range ends above it.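

On the carbonyl carbon, joining the same atoms differently within the six-membered ring gives an at least 590-fold lower number from compound 2 to compound 4 (2.77 log units; beyond the scatter) in this assay. The heavy-atom count, hydrogen-bond donor and acceptor counts, and net charge of the group do not change, so these counts alone do not separate the pair. Compound 4 is the only measured number so far, and the other values shown are limits: the limit of > 100000 nM in this assay, at which 3 of the 4 values shown sit.

From the compounds shown here alone, whether a piperidine or morpholine ring on the same carbonyl carbon would keep such a number remains open. So does the contribution of the ring's oxygen.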